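The compounds below may be only part of what the source reports. "The series", "measured", "known", "first", "only" and "open" are said of these compounds alone.

Measured so far in a functional assay on SF-268 cells (Homo sapiens) for inhibition, read by sulforhodamine B assay, with a stated time of 48 h; a lower number here means a stronger inhibitor of growth, a higher number a weaker inhibitor of growth:
compound 1 `Cc1cc(O)cc(-c2nn(CC#N)cc2-c2ccnc(-c3ccc(Oc4ccccc4)cc3)c2)c1` — 3960 nM
compound 2 `COc1cc(C)cc(-c2nn(CC#N)cc2-c2ccnc(-c3ccc(N(C)C)cc3)c2)c1` — 478 nM

Compound 2 has the lower of these two numbers, and compound 1 sits far enough above it to lie beyond the usual scatter. Compound 3 `Cc1cc(O)cc(-c2nn(CC#N)cc2-c2ccnc(-c3ccc(N(C)C)cc3)c2)c1` differs from compound 2 in one place: hydrogen in place of methyl on an oxygen on an aromatic ring. Going by the values given here, no measured pair shows this single change on its own, so its size cannot be read from these data; compound 1 also carries a hydroxy group, but it differs from compound 2 in a second place as well. The change is expected to bring a small step at most, if any, likely toward a slightly higher number. Compound 3 is estimated at 650 nM, with a range from 220 nM to 2000 nM. This estimate corresponds to an expected step of a 1.4-fold higher number from compound 2 to compound 3 (0.13 log units; within the scatter) in this assay.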

Compound 3, concentration for 50% growth inhibition: 3550 nM
For compound 3 the middle estimate is 5.5-fold (0.74 log units) below the measured one; the measured number lies above the stated range.
By their numbers in this assay, from the lowest: compound 2; then compounds 3 and 1 (each within the scatter of the next).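

In this assay the change from methoxy to hydroxy gives a 7.4-fold higher number from compound 2 to compound 3 (0.87 log units; beyond the scatter) and so is far from neutral: the methyl on this oxygen matters for growth inhibition. With the hydroxy group present, dimethylamino in place of phenoxy gives a 1.1-fold lower number from compound 1 to compound 3 (0.05 log units; within the scatter) and makes no difference beyond the scatter. Nothing available here explains the loss from removing the methyl.

On these data alone, whether a longer chain on this oxygen, such as ethoxy, would keep the lower number of compound 2 remains open. So does whether phenoxy and dimethylamino would also match when methoxy is present.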